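The compounds below may be only part of what the source reports. "The series", "measured", "known", "first", "only" and "open" are said of these compounds alone.

Of the compounds shown here, three on a shared core have numbers so far. In a functional assay on PANC-1 cells (Homo sapiens) for inhibition, read by MTT assay, with a stated time of 24 h (on this read-out higher numbers stand for weaker inhibition and lower numbers for stronger inhibition), compound 1 `CC1(C)[C@H]2CC[C@]1(C)N(Cc1cn(-c3ccccc3F)nn1)C(=O)C2` gives 150 nM while compound 2 `CC1(C)[C@H]2CC[C@]1(C)N(Cc1cn(-c3ccc(F)cc3)nn1)C(=O)C2` gives 110 nM and compound 3 `CC1(C)[C@H]2CC[C@]1(C)N(Cc1cn(-c3ccc(Br)cc3)nn1)C(=O)C2` gives 200 nM on the same read-out. Compound 3 therefore sits within the scatter of both others. Compound 4 `CC1(C)[C@H]2CC[C@]1(C)N(Cc1cn(-c3ccccc3O)nn1)C(=O)C2` has 2-hydroxyphenyl in place of 4-bromophenyl on an aromatic nitrogen. Earlier changes to the group on that nitrogen stayed small (a 1.3-fold higher number from compound 1 to compound 3 (0.12 log units; within the scatter)) and (a 1.8-fold higher number from compound 2 to compound 3 (0.26 log units; within the scatter)) and (a 1.4-fold lower number from compound 1 to compound 2 (0.13 log units; within the scatter)), all within the scatter. Among the compounds with values here, no measured compound carries a hydroxy group, so that feature remains untested. No step beyond the scatter is therefore expected in this assay for this swap. The expected change is small (a 1.3-fold lower number from compound 3 to compound 4 (0.12 log units; within the scatter)) and without a clear direction. For compound 4 the estimate is 150 nM with an expected range of 60 nM to 400 nM once measured.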

Compound 4, half-maximal inhibitory concentration: 230 nM
Compound 4: middle estimate off by 1.5-fold (0.19 log units), on the low side; low and high end bracket the measured number.
By their numbers in this assay, from the lowest: compounds 2, 1, 3 and 4 (each within the scatter of the next, the first and the last beyond it).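

Within the data shown here, putting 2-hydroxyphenyl on the aromatic nitrogen brings in a hydrogen-bond donor, which no earlier compound had, yet in this assay the number barely shifts: a 1.2-fold higher number from compound 3 to compound 4 (0.06 log units; within the scatter) and a 1.5-fold higher number from compound 1 to compound 4 (0.19 log units; within the scatter). Only the comparison with the 4-fluorophenyl compound passes the scatter, and modestly: a 2.1-fold higher number from compound 2 to compound 4 (0.32 log units; beyond the scatter). No measured evidence explains these small differences. Still open, from the compounds shown here alone, is whether an amine or a carboxylic acid in place of the hydroxy group would keep the number in this range.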